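This account rests on a few compounds, and the source may have more. Where it says the series, first, only, none or still open, it means among the compounds named here.

Compound 1, `Cc1cc(/C=C/c2ccc(O)cc2)[nH]n1`, gives 80000 nM in an ADME assay on MDCK cells (Canis lupus familiaris) for cytotoxicity, read by MTT assay, with a stated time of 72 h; a higher number here means a weaker inhibitor, a lower number a stronger inhibitor. Compound 2, `COc1ccc(/C=C/c2cc(C)n[nH]2)cc1`, gives 16500 nM. Compound 3, `COc1ccc(/C=C/c2cc(C)no2)cc1`, gives 70200 nM. Compound 4, `Cc1cc(/C=C/c2ccc(O)cc2)on1`, has not been measured.

Compound 1 and compound 2 share one core and differ in a single place: hydrogen in place of methyl on an oxygen on an aromatic ring. That change produced a 4.8-fold higher number from compound 2 to compound 1 (0.69 log units; beyond the scatter). Compound 3 is built on a second core; the difference between the two cores is not broken down here. In this assay compound 3 and compound 1 give numbers within the usual scatter of each other, so nothing separates them.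

Compound 4 stands to compound 3 as compound 1 stands to compound 2: hydrogen in place of methyl on an oxygen on an aromatic ring. The surroundings of the place are the same in both pairs, so this is the same kind of change on a different core. On that basis, the step is expected to be a 3.6-fold higher number from compound 3 to compound 4 (0.55 log units; beyond the scatter), resting on a 4.8-fold higher number from compound 2 to compound 1 (0.69 log units; beyond the scatter). Compound 4 is therefore estimated at 250000 nM, with a range from 100000 nM to 600000 nM. Such a high number may lie at the edge of what the assay can report, so a limit rather than a number is possible.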

Compound 4, half-maximal inhibitory concentration: 58300 nM
Compound 4: the middle estimate sits 4.3-fold (0.63 log units) above what was measured; measured number below the stated range.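

On the second core, the change from methoxy to hydroxy in this assay gives a 1.2-fold lower number from compound 3 to compound 4 (0.08 log units; within the scatter), so on this core the swap has no effect that can be told from the scatter. Within the data shown here, the same change therefore did not carry over from one core to the other, and a step seen on one core proved a poor guide to the other: the same change on two cores in this assay, a 4.8-fold higher number (0.69 log units; beyond the scatter) from compound 2 to compound 1 and a 1.2-fold lower number (0.08 log units; within the scatter) from compound 3 to compound 4, 5.8-fold (0.77 log units) apart, beyond the scatter of two such steps This comparison rests on only one pair of compounds per core, so it shows that the core can matter for this change, but it does not show which part of the core is responsible or why.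

The compounds shown leave open whether a longer chain on that oxygen, such as ethoxy, would also give different results on the two cores. They also leave open how an amine in place of the hydroxy group would behave on each core.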